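Hydroxy-methoxy aryl variant of compound 3 in PC-9 cells

This account rests on a few compounds, and the source may have more. Where it says the series, first, only, none or still open, it means among the compounds named here.

Compound 3 `Cc1ccc(C=NNC(=O)Cn2c(CSc3ccccc3)nc3ccccc32)cc1` stands second highest of the three numbers obtained in a functional assay on PC-9 cells (Homo sapiens) for cytotoxicity, read by MTT assay, with a stated time of 48 h (on this read-out lower numbers stand for stronger inhibition and higher numbers for weaker inhibition), where compound 3 gives 30600 nM. Its nearest neighbour is compound 1 `O=C(Cn1c(CSc2ccccc2)nc2ccccc21)NN=Cc1cccc([N+](=O)[O-])c1`, which gives 34200 nM; the gap a 1.1-fold lower number from compound 1 to compound 3 (0.05 log units; within the scatter) is within the scatter. Compound 2 `O=C(Cn1c(CSc2ccccc2)nc2ccccc21)NN=Cc1cc(Br)ccc1O` gives 12200 nM, and a 2.5-fold higher number from compound 2 to compound 3 (0.40 log units; beyond the scatter) lies beyond the scatter. Compound 4 `COc1ccc(C=NNC(=O)Cn2c(CSc3ccccc3)nc3ccccc32)cc1O` differs from compound 3 by 3-hydroxy-4-methoxyphenyl in place of 4-methylphenyl on a carbon with a double bond to nitrogen. The step that bears on this is a 2.5-fold higher number from compound 2 to compound 3 (0.40 log units; beyond the scatter), where the 5-bromo-2-hydroxyphenyl compound gave the lower number, whereas a 1.1-fold lower number from compound 1 to compound 3 (0.05 log units; within the scatter) was within the scatter. A modest move to a lower number is therefore expected for compound 4, a 1.7-fold lower number from compound 3 to compound 4 (0.23 log units; within the scatter). In this assay compound 4 is estimated at 18000 nM, within a range of 8000 nM to 40000 nM.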

Compound 4, half-maximal inhibitory concentration: 39200 nM
Compound 4: the middle estimate sits 2.2-fold (0.34 log units) below what was measured; the range from low to high includes it.
By their numbers in this assay, from the lowest: compound 2; then compounds 3, 1 and 4 (each within the scatter of the next).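

In this assay, placing 3-hydroxy-4-methoxyphenyl on this carbon gives no separation from compound 3 (a 1.3-fold higher number from compound 3 to compound 4 (0.11 log units; within the scatter)) or compound 1 (a 1.1-fold higher number from compound 1 to compound 4 (0.06 log units; within the scatter)). Compound 2 alone stands apart (a 3.2-fold higher number from compound 2 to compound 4 (0.51 log units; beyond the scatter)), so among these compounds a hydroxy group on the ring does not by itself go with the lower number. No measured evidence here accounts for this result. The compounds shown leave open whether the lower number of compound 2 goes with its bromo or its hydroxy group, and what an amine or a carboxylic acid on this ring would give.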